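This account rests on a few compounds, and the source may have more. Where it says the series, first, only, none or still open, it means among the compounds named here.

Among the compounds with values here, in an ADME assay on HEK293 cells (Homo sapiens) for cytotoxicity, read by MTT assay, with a stated time of 48 h (a higher number here means a weaker inhibitor, a lower number a stronger inhibitor), compound 1 `CN(C)CCn1c(N)c(-c2nc3ccccc3[nH]2)c2nc(C#N)c(C#N)nc21` gives 9730 nM, the only actual number so far. Compound 2 `N#Cc1nc2c(-c3nc4ccccc4[nH]3)c(N)n(CCO)c2nc1C#N` sits at > 50000 nM, a limit of the assay. Compound 3 `CCCCn1c(N)c(-c2nc3ccccc3[nH]2)c2nc(C#N)c(C#N)nc21` sits at > 50000 nM, also a limit. On the chain, hydroxy in place of dimethylamino gives an at least 5.1-fold higher number from compound 1 to compound 2 (0.71 log units; beyond the scatter), and ethyl in its place gives an at least 5.1-fold higher number from compound 1 to compound 3 (0.71 log units; beyond the scatter). Compound 4 `CN(C)CCn1c(N)c(-c2nc3ccccc3s2)c2nc(C#N)c(C#N)nc21` keeps the 2-(dimethylamino)ethyl group and differs on an aromatic carbon: 1,3-benzothiazol-2-yl in place of 1H-benzimidazol-2-yl on an aromatic carbon. Neither measured step touches that place, so neither gives a size for this change. Compound 1 at 9730 nM is therefore the starting point, and no step beyond the scatter is expected in this assay. The expected step is a 1.1-fold lower number from compound 1 to compound 4 (0.03 log units; within the scatter). The estimate for compound 4 is 9000 nM, with an expected range of 3000 nM to 30000 nM.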

Compound 4, half-maximal inhibitory concentration: 11800 nM
For compound 4 the middle estimate is 1.3-fold (0.12 log units) below the measured one; low and high end bracket the measured number.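

In this assay, 1,3-benzothiazol-2-yl in place of 1H-benzimidazol-2-yl gives a 1.2-fold higher number from compound 1 to compound 4 (0.08 log units; within the scatter). Within the data shown here, this is the first reading at this aromatic carbon: sulfur enters and the hydrogen-bond donor of 1H-benzimidazol-2-yl is gone, yet the two compounds are not separated. The chain steps from compound 1 lie beyond the scatter, while this step does not.

On these data alone, a phenyl group at this aromatic carbon remains open, as does a longer amine chain in place of 2-(dimethylamino)ethyl. Compound 2 and compound 3 are limits, and the step between them cannot be read: the limit of > 50000 nM in this assay, at which 2 of the 4 values shown sit.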